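Swapping a nitrile for fluorine on the pendant aryl ring

The source may hold more compounds than are shown below. What is called first, only, known or untested is meant among the compounds shown, and "the series" means these compounds.

Compound 1, `Cn1cc(-c2nn(C)c3cc(N)ccc23)cn1`: > 384000 nM
Compound 2, `N#Cc1ccc(-n2cc(-c3n[nH]c4cc(Cl)c(N[C@@H]5CCNC5)cc34)cn2)cc1`: 700 nM

Within the data shown here, in an assay on isolated protein for inhibition of tyrosine-protein kinase receptor UFO (Homo sapiens), with a stated time of 1.5 h (a lower number here means a stronger inhibitor, a higher number a weaker inhibitor), compound 2 gives 700 nM, the only real number among the two measured compounds. Compound 1 gives > 384000 nM, which is a limit of the assay rather than a number (the limit of > 384000 nM in this assay, at which 1 of the 2 values shown sits). Compound 3, `Fc1ccc(-n2cc(-c3n[nH]c4cc(Cl)c(N[C@@H]5CCNC5)cc34)cn2)cc1`, differs from compound 2 by fluoro in place of cyano on an aromatic carbon. Among the measured compounds shown here, with no measured step to lean on, the change is expected to move the reading by a small amount in this assay, likely toward weaker inhibition. The expected step from compound 2 to compound 3 is a 1.7-fold higher number from compound 2 to compound 3 (0.23 log units; within the scatter). Compound 3 is estimated at 1200 nM, between 400 nM and 4000 nM.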

Compound 3, half-maximal inhibitory concentration: 2300 nM
Compound 3: middle estimate off by 1.9-fold (0.28 log units), on the low side; measured number inside the range.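

On the aromatic carbon para to a large group, fluoro in place of cyano gives a 3.3-fold higher number from compound 2 to compound 3 (0.52 log units; beyond the scatter). This shows that the group at this position affects the reading, with the 4-cyanophenyl compound the stronger inhibitor of this pair, although the step is modest. No measurement shown bears on why the reading moves. A single pair cannot show whether the nitrile is especially favourable here or fluoro is simply less so. Also open, as far as these compounds go, is how a carboxylic acid or a methoxy group would read on the same aromatic carbon.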